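Swapping the trimethoxyphenyl for phenyl on compound 2

The source may report more compounds than this note shows. Statements on the series, on what has been measured and on what is new or still open speak of the compounds shown alone.

Of the compounds shown here, three sharing one core have been measured in a functional assay on THP-1 cells (Homo sapiens) for inhibition, read by sulforhodamine B assay, with a stated time of 48 h, tested at 50 uM; on this read-out higher numbers stand for more inhibition of growth at the one concentration tested and lower numbers for less inhibition of growth. Compound 2 `COc1cc(/C=C/C(=O)/C=C/c2cc(OC)c(OC)c(OC)c2)ccc1OCc1cn(CCCCCOc2cc(=O)oc3ccccc23)nn1` gives 55%, the second highest of the three numbers. Its nearest neighbour is compound 1 `COc1cc(/C=C/C(=O)/C=C/c2ccccc2)ccc1OCc1cn(CCCOc2cc(=O)oc3ccccc23)nn1`, which in this assay gives 48%, within the scatter of compound 2. The furthest is compound 3 `COc1cc(/C=C/C(=O)/C=C/c2cc(OC)c(OC)c(OC)c2)ccc1OCc1cn(CCCOc2cc(=O)oc3ccccc23)nn1`, which in this assay gives 79%, beyond the scatter above compound 2.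

Compound 4 `COc1cc(/C=C/C(=O)/C=C/c2ccccc2)ccc1OCc1cn(CCCCCOc2cc(=O)oc3ccccc23)nn1` has not been measured. It differs from compound 2 in one place: phenyl in place of 3,4,5-trimethoxyphenyl on a double-bonded chain carbon bound to a double-bonded chain carbon

For the measured compounds named here, one measured step bears on this change, in the opposite direction: a number 31 percentage points higher from compound 1 to compound 3 (beyond the scatter). Reversing that exchange on compound 2 is therefore expected to cost a large share of its inhibition. Compound 4 is expected to give 30%, within 15% to 48%, which means an expected step of a number 25 percentage points lower from compound 2 to compound 4 (beyond the scatter).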

Compound 4, percent growth inhibition at one concentration: 26%
The estimate for compound 4 lay 4 percentage points above the measured number, within the range that was stated.
By their numbers in this assay, from the lowest: compound 4; then compounds 1 and 2 (each within the scatter of the next); then compound 3.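

In this assay, the exchange of 3,4,5-trimethoxyphenyl for phenyl on a double-bonded chain carbon bound to a double-bonded chain carbon now has a reading on a second core: a number 29 percentage points lower from compound 2 to compound 4 (beyond the scatter). For the compounds shown here, until this result, the link between this group and higher inhibition of growth rested on a single pair of compounds. It now rests on two pairs, and the size of the step does not depend on which of the two cores carries the group: the same change on two cores in this assay, a number 31 percentage points higher (beyond the scatter) from compound 1 to compound 3 and a number 29 percentage points higher (beyond the scatter) from compound 4 to compound 2, 2 percentage points apart, within the scatter of two such steps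

The compounds shown have only phenyl or 3,4,5-trimethoxyphenyl at this place, so it remains open what a ring with a single methoxy group or with an amine would give. Going by these compounds, it also remains open whether a step of this size would appear on a core with a longer chain than that of compound 2.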